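This account rests on a few compounds, and the source may have more. Where it says the series, first, only, none or still open, it means among the compounds named here.

Three compounds share a sulfone-linked core, measured in a functional assay on HCT-116 cells (Homo sapiens) for cytotoxicity, read by MTT assay, with a stated time of 72 h; on this read-out lower numbers stand for stronger inhibition of growth and higher numbers for weaker inhibition of growth. Compound 1 `COc1ccc(CS(=O)(=O)/C=C/c2c(OC)cccc2OC)cc1[N+](=O)[O-]` gives 10200 nM. Compound 2 `COc1ccc(CS(=O)(=O)/C=C/c2ccc(OC)c(OC)c2OC)cc1[N+](=O)[O-]` gives 27900 nM; the difference between the cores of compound 1 and compound 2 is not broken down here. Compound 3 `COc1ccc(CS(=O)(=O)/C=C/c2ccc(OC)c(OC)c2OC)cc1N` gives 5310 nM. The change from compound 2 to compound 3 is amino in place of nitro on an aromatic carbon, and it produced a 5.3-fold lower number from compound 2 to compound 3 (0.72 log units; beyond the scatter).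

Compound 4 `COc1ccc(CS(=O)(=O)/C=C/c2c(OC)cccc2OC)cc1N` has not yet been measured in this assay. It differs from compound 1 by amino in place of nitro on an aromatic carbon, the same change made from compound 2 to compound 3. On that single precedent, compound 4 is expected to show a 4.3-fold lower number from compound 1 to compound 4 (0.63 log units; beyond the scatter), because compound 3 showed a 5.3-fold lower number from compound 2 to compound 3 (0.72 log units; beyond the scatter). Compound 4 is therefore estimated at 2400 nM, with a range from 900 nM to 7000 nM.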

Compound 4, concentration for 50% growth inhibition: 20 nM
Estimate against measurement, compound 4: 120-fold (2.08 log units) above; the whole stated range lies above it.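

On the core of compound 1, amino in place of nitro gave a 510-fold lower number from compound 1 to compound 4 (2.71 log units; beyond the scatter) in this assay. The direction of the change carried over from one core to the other, but its size did not: the same change on two cores in this assay, a 5.3-fold lower number (0.72 log units; beyond the scatter) from compound 2 to compound 3 and a 510-fold lower number (2.71 log units; beyond the scatter) from compound 1 to compound 4, 97-fold (1.99 log units) apart, beyond the scatter of two such steps With only these two pairs, this shows that the size of the step depends on the core, but it does not show which difference between the two cores matters, and it gives no rule for predicting the step on a further core.

The compounds shown leave open whether the large step is tied to the amino group alone or to its pairing with the core of compound 1. They also leave open how an acetamide or a hydroxyl group in place of the amino would behave on either core.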